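A few compounds are considered here, and "the series" means these few. Any claim that something is new, unique, unknown or untested is made for them only; others in the source may bear on it.

Measured so far:
compound 1, `Sc1nnc(/C=C/c2ccccc2)o1`: in an assay (Populus sieboldii x Populus grandidentata) for inhibition of Trans-cinnamate 4-monooxygenase (Populus kitakamiensis), with a stated time of 60 min (a lower number here means a stronger inhibitor, a higher number a weaker inhibitor), compound 1 reaches only the assay limit, > 100000 nM.
compound 2, `Cc1cccc(-c2nnc(S)o2)c1`: in this assay compound 2 gives 1100 nM.

Among the measured compounds shown here, compound 2 thus holds the only real number in this assay; compound 1 stands at the limit of > 100000 nM in this assay, at which 1 of the 2 values shown sits. Compound 3, `COc1cccc(-c2nnc(S)o2)c1`, differs from compound 2 by methoxy in place of methyl on an aromatic carbon. For the measured compounds named here, no measured pair covers this change, so the step from compound 2 to compound 3 is expected to be small, within the usual scatter, a 1.2-fold higher number from compound 2 to compound 3 (0.07 log units; within the scatter). In this assay compound 3 is estimated at 1300 nM, with a range from 400 nM to 4000 nM.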

Compound 3, half-maximal inhibitory concentration: 6100 nM
For compound 3 the middle estimate is 4.7-fold (0.67 log units) below the measured one, outside the stated range (above it).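

On an aromatic carbon of a six-membered aromatic ring of carbon only, meta to a group of 6 heavy atoms, methoxy in place of methyl is not a neutral exchange in this assay: the change gives a 5.5-fold higher number from compound 2 to compound 3 (0.74 log units; beyond the scatter). Among the compounds shown here, as the only measured step, it shows that this position responds to the group it carries, with methyl giving the lower number of the two. No data given here bear on the cause of this step.

Open: how chlorine, an amine or a longer chain would behave at this position, and whether methoxy gives a similar step elsewhere on the ring.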